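Notes on a 4-bromophenyl analogue of an inactive compound

The compounds below may be only part of what the source reports. "The series", "measured", "known", "first", "only" and "open" are said of these compounds alone.

So far two compounds sharing one core have been read in a functional assay on A549 cells (Homo sapiens) for antiproliferative activity, read by MTT assay (a higher number here means a weaker inhibitor, a lower number a stronger inhibitor), and only one of them carries a number. Compound 1 (`COc1ccc(-n2cc(COc3ccc(/C=C/C(=O)c4cc5c(cc4O)OC(C)(C)CC5)cc3)nn2)c([N+](=O)[O-])c1`) gives 99500 nM as its half-maximal inhibitory concentration. Compound 2 (`CC1(C)CCc2c(ccc(C(=O)/C=C/c3ccc(OCc4cn(-c5ccc(Cl)cc5)nn4)cc3)c2O)O1`) is recorded as "not active" (no number reported) with no number attached, so it has no exact place on the scale. Going by the values given here, no step between measured compounds is available to calibrate a change.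

Compound 3 (`CC1(C)CCc2c(ccc(C(=O)/C=C/c3ccc(OCc4cn(-c5ccc(Br)cc5)nn4)cc3)c2O)O1`) is the next to be read. The change is bromo in place of chloro on an aromatic carbon and amounts to bromo in place of chloro on an aromatic carbon, para to a large group. No shift beyond the usual scatter is expected from this swap, in either direction. Among the compounds with values here, that expectation rests on compound 2 being recorded as "not active" (no number reported) and on compound 1 reading 99500 nM as the only number available. A result without a number would be no surprise. In this assay compound 3 is expected at about 90000 nM (estimated range 30000 nM to 200000 nM).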

Compound 3, half-maximal inhibitory concentration: 129000 nM
Beside the measured number, compound 3's estimate is 1.4-fold (0.16 log units) below it; the measured number falls inside the stated range.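

No step can be read from this result: compound 2 carries no number in this assay and compound 1 differs from compound 3 in more than one place. From the compounds shown here alone, what 4-chlorophenyl to 4-bromophenyl does to the read-out stays open. No supporting data bear on the reading for compound 3.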